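The source may report more compounds than this note shows. Statements on the series, on what has been measured and on what is new or still open speak of the compounds shown alone.

Working notes on the series. Within the data shown here, compound 3 `Cc1cccc(NS(=O)(=O)c2cccc(CCCCCCNC(=O)/C=C/c3cccnc3)c2)c1` sits at the top of the three numbers so far in an assay on isolated protein for inhibition of Nicotinamide phosphoribosyltransferase (Homo sapiens), read by WST assay, with stated times of 60 min, 5 min and 30 min, in the presence of a further agent that is not named here (on this read-out higher numbers stand for weaker inhibition and lower numbers for stronger inhibition), where compound 3 gives 12.3 nM. Its nearest neighbour is compound 1 `O=C(/C=C/c1cccnc1)NCCCCCCc1cccc(S(=O)(=O)Nc2ccccc2)c1`, which in this assay gives 10.5 nM; the two lie within the scatter of each other, as a 1.2-fold higher number from compound 1 to compound 3 (0.07 log units; within the scatter) shows. The furthest is compound 2 `Cc1ccccc1NS(=O)(=O)c1cccc(CCCCCCNC(=O)/C=C/c2cccnc2)c1`, which in this assay gives 5.08 nM; the step of a 2.4-fold higher number from compound 2 to compound 3 (0.38 log units; beyond the scatter) is modest but beyond the scatter, and the step of a 2.1-fold lower number from compound 1 to compound 2 (0.32 log units; beyond the scatter) is of like size in the other direction.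

Compound 4 `CCc1ccc(NS(=O)(=O)c2cccc(CCCCCCNC(=O)/C=C/c3cccnc3)c2)cc1` differs from compound 3 in one place: 4-ethylphenyl in place of 3-methylphenyl on a sulfonamide nitrogen. Among the measured compounds shown here, the only measured step at the same place is the one from compound 2 to compound 3, a modest one. For the measured compounds named here, no compound yet carries an ethyl, and no compound carries a substituent in the 4-position of that phenyl, so the step to compound 4 in this assay has little to rest on. The working expectation is a number close to that of compound 3, with no step beyond the scatter in either direction, the estimated step being a 1.1-fold higher number from compound 3 to compound 4 (0.06 log units; within the scatter). Compound 4 is therefore expected to give about 14 nM in this assay, within a range of 6 nM to 35 nM.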

Compound 4, half-maximal inhibitory concentration: 31.5 nM
Beside the measured number, compound 4's estimate is 2.3-fold (0.35 log units) below it, and the stated range covers the measured number.
By their numbers in this assay, from the lowest: compound 2; then compounds 1 and 3 (each within the scatter of the next); then compound 4.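

In this assay, the phenyl on the sulfonamide nitrogen now carries a substituent that weakens inhibition relative to the plain phenyl (a 3.0-fold higher number from compound 1 to compound 4 (0.48 log units; beyond the scatter)), whereas the 3-methylphenyl of compound 3 stayed within the scatter of that phenyl and the 2-methylphenyl of compound 2 gave a lower number. The 4-ethylphenyl also widens the span at this place (a 6.2-fold higher number from compound 2 to compound 4 (0.79 log units; beyond the scatter); a 2.6-fold higher number from compound 3 to compound 4 (0.41 log units; beyond the scatter)), so compound 4 gives the highest number of the four, with its steps to all three others beyond the scatter. Nothing available explains the rise.

In compound 4 the ethyl and its place on the ring change together, so their shares remain unseparated; a methyl in place of the ethyl of 4-ethylphenyl would bear on this. As far as these compounds go, how an amine or a carboxylic acid on that phenyl would read also remains open.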